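Acetylation of a Ring Hydroxyl and Cytotoxicity on SEM Cells

A few compounds are considered here, and "the series" means these few. Any claim that something is new, unique, unknown or untested is made for them only; others in the source may bear on it.

Measured so far:
compound 1 `COc1ccc(C(=O)O[C@H]2CC(C)=C[C@@H](OC(C)=O)[C@@]3(C)[C@@H](OC(C)=O)C[C@@](O)(C(C)C)[C@H]23)cc1` with 32900 nM
compound 2 `COc1ccc(C(=O)O[C@H]2CC(C)=C[C@H](OC(C)=O)[C@]3(C)[C@@H]2[C@](O)(C(C)C)C[C@@H]3O)cc1` with 26500 nM
compound 3 `COc1ccc(C(=O)O[C@H]2CC(C)=C[C@@H](O)[C@@]3(C)[C@@H](OC(C)=O)C[C@@](O)(C(C)C)[C@H]23)cc1` with a limit of > 100000 nM

All three were tested in a functional assay on SEM cells (Homo sapiens) for cytotoxicity, read by MTT assay, with a stated time of 72 h; on this read-out lower numbers stand for stronger inhibition and higher numbers for weaker inhibition. Compound 1 gives 32900 nM. Compound 2 gives 26500 nM. For compound 3 the assay reports only a limit, > 100000 nM, at which the value sits (the limit of > 100000 nM in this assay, at which 1 of the 3 values shown sits). Compound 1 and compound 2 lie within the scatter of each other.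

Compound 1 and compound 3 share a core and differ in one place, (acetyl in place of hydrogen on an oxygen on a saturated carbon), and this change gave an at least 3.0-fold lower number from compound 3 to compound 1 (0.48 log units; beyond the scatter). Compound 2 and compound 3 have the same atoms joined differently; the difference between the two cores is not broken down here.

Compound 4 `COc1ccc(C(=O)O[C@H]2CC(C)=C[C@H](OC(C)=O)[C@@]3(C)[C@@H](OC(C)=O)C[C@@](O)(C(C)C)[C@H]23)cc1` has not yet been measured in this assay. It differs from compound 2 by acetyl in place of hydrogen on an oxygen on a saturated carbon, the same change as that from compound 3 to compound 1, at the same place. Resting on the step seen from compound 3 to compound 1, an at least 3.0-fold lower number from compound 3 to compound 1 (0.48 log units; beyond the scatter), a step of a 2.2-fold lower number from compound 2 to compound 4 (0.34 log units; beyond the scatter) is expected from compound 2 to compound 4. This expectation is held back: the core of compound 2 is not the core of compound 1, and the earlier step is known only as a limit. Compound 4 is therefore estimated at 12000 nM, within a range from 4000 nM to 35000 nM.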

Compound 4, half-maximal inhibitory concentration: 15000 nM
Beside the measured number, compound 4's estimate is 1.3-fold (0.10 log units) below it; measured number inside the range.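

In this assay, the hydroxy to acetoxy change on the core of compound 2 gave a 1.8-fold lower number from compound 2 to compound 4 (0.25 log units; within the scatter), so the clear step seen on the other core was not repeated beyond the scatter. The earlier step rests on compound 3, which carries only a limit, > 100000 nM. The data therefore show neither that the change carries over in full nor that its size depends on the core: the same change on two cores in this assay, an at least 3.0-fold lower number (0.48 log units; beyond the scatter) from compound 3 to compound 1 and a 1.8-fold lower number (0.25 log units; within the scatter) from compound 2 to compound 4; the limit leaves it open whether they differ

As far as these compounds go, a change of configuration alone, at a saturated ring carbon, gave a 2.2-fold lower number from compound 1 to compound 4 (0.34 log units; beyond the scatter), so it remains open how far this stereocentre shapes the effect of the acetyl group on each core. Also open, from the compounds shown here alone, is whether a longer acyl chain or an amine in place of the acetyl on that oxygen would follow the same course in this assay.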